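This account rests on a few compounds, and the source may have more. Where it says the series, first, only, none or still open, it means among the compounds named here.

Measured so far:
- compound 1 `O=C1c2ccc(OCc3cccc(-c4ccc(Cl)cc4F)c3)cc2CN1C1CCCC1`: "not determined" (no result reported)
- compound 2 `O=C(O)c1cc(-c2cccc(COc3ccc4c(=O)n(C5CCC5)sc4c3)c2)ccc1Cl`: 83%

Compound 1 carries no number in an assay on HEK293 cells for positive allosteric modulation of metabotropic glutamate receptor 2 (Rattus norvegicus), read by thallium flux; a higher number here means a larger maximal response, a lower number a smaller maximal response; the result is recorded as "not determined" (no result reported), so there is nowhere to place it on the scale. Compound 2, which sits on a different core but likewise ends in a terminal ring bearing a carboxylic acid, gives 83% in this assay and is the only anchor in the set.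

Compound 3 `COc1ccc(-c2cccc(COc3ccc4c(c3)CN(C3CCCC3)C4=O)c2)cc1C(=O)O` keeps the core of compound 1 and changes the terminal ring:
3-carboxy-4-methoxyphenyl in place of 4-chloro-2-fluorophenyl on an aromatic carbon
With compound 1 unmeasured, no direction or size of step in this assay can be read from the pair; the expectation for compound 3 rests on compound 2 alone. Compound 3 is estimated to reach a maximal response near that of compound 2, at 80%, with a plausible range from 55% to 105%, because compound 2 with its acid-bearing terminal ring gives 83%.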

Compound 3, largest response reached (reported as percent of maximum), in percent of the reference or control that the assay uses: 78%
The estimate for compound 3 lay 2 percentage points above the measured number, and the stated range covers the measured number.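

In this assay compound 1 stands as "not determined" (no result reported) and compound 3 gives 78%, so no step can be read between them. The compounds shown leave open what replacing 4-chloro-2-fluorophenyl with 3-carboxy-4-methoxyphenyl does to the maximal response on the core of compound 1. No supporting evidence bears on this result.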